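Removing the hydroxyl from the amide side chain

A few compounds are considered here, and "the series" means these few. Any claim that something is new, unique, unknown or untested is made for them only; others in the source may bear on it.

Of the compounds shown here, three sharing one core have been measured in a functional assay on MKN-45 cells (Homo sapiens) for antiproliferative activity, read by MTT assay, with a stated time of 72 h, tested at 10 uM; on this read-out higher numbers stand for more inhibition at the one concentration tested (going by the name of the read-out) and lower numbers for less inhibition. Compound 1 `CC(C)C(=O)Nc1cc(Oc2ccc(Nc3nccc4[nH]cc(-c5ccc(F)cc5)c(=O)c34)cc2F)ccn1` gives 95.4%. Compound 2 `CC(C)(O)C(=O)Nc1cc(Oc2ccc(Nc3nccc4[nH]cc(-c5ccc(F)cc5)c(=O)c34)cc2F)ccn1` gives 57.8%, and compound 3 `O=C(CO)Nc1cc(Oc2ccc(Nc3nccc4[nH]cc(-c5ccc(F)cc5)c(=O)c34)cc2F)ccn1` gives 63%. Compound 3 stands second highest of the three numbers, within the scatter of compound 2 and well below compound 1, as the step of a number 32.4 percentage points lower from compound 1 to compound 3 (beyond the scatter) shows. The new compound 4 `O=C(Nc1cc(Oc2ccc(Nc3nccc4[nH]cc(-c5ccc(F)cc5)c(=O)c34)cc2F)ccn1)C1CC1` differs from compound 3 in one place: cyclopropyl in place of hydroxymethyl on a carbonyl carbon. For the measured compounds named here, two measured steps bear on this. The step of a number 32.4 percentage points lower from compound 1 to compound 3 (beyond the scatter) joins an isopropyl amide to a hydroxymethyl amide, and the step of a number 37.6 percentage points lower from compound 1 to compound 2 (beyond the scatter) joins the same isopropyl amide to one carrying a hydroxy group. In both, the compound without a hydroxy group gives the higher number. Cyclopropyl, like isopropyl, carries no hydroxy group, so the change from compound 3 to compound 4 is expected to run the opposite way, as a large rise. Compound 4 is therefore expected to give 88%, within 70% to 98%, a step of a number 25 percentage points higher from compound 3 to compound 4 (beyond the scatter).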

Compound 4, a percentage reported as inhibition, at one concentration (the size of the read-out at that concentration, not a potency): 81.8%
Estimate against measurement, compound 4: 6.2 percentage points above, and the stated range covers the measured number.
By their numbers in this assay, from the lowest: compounds 2 and 3 (each within the scatter of the next); then compound 4; then compound 1.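

In this assay, putting cyclopropyl in place of hydroxymethyl on the carbonyl carbon gives a number 18.8 percentage points higher from compound 3 to compound 4 (beyond the scatter) and putting it in place of 1-hydroxy-1-methylethyl gives a number 24 percentage points higher from compound 2 to compound 4 (beyond the scatter) so a second group without a hydroxy group also stands above both groups that carry one, and none of the four compounds goes against this pattern. The absence of a hydroxy group does not settle the number on its own, though: cyclopropyl in place of isopropyl gives a number 13.6 percentage points lower from compound 1 to compound 4 (beyond the scatter) and so the two groups without a hydroxy group are separated as well. At this position, then, the result depends on more than whether a hydroxy group is present.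

As far as these compounds go, how an amine such as aminomethyl or a longer chain such as n-butyl would compare on the same carbonyl carbon remains open. Nothing shown here gives a reason for any of these differences.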